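Compound 3 to compound 4: a swap within the chain

The source may report more compounds than this note shows. Statements on the series, on what has been measured and on what is new or still open speak of the compounds shown alone.

Measured so far in a functional assay on HepG2 cells (Homo sapiens) for antiproliferative activity, read by MTT assay, with a stated time of 48 h (on this read-out higher numbers stand for weaker inhibition and lower numbers for stronger inhibition), as follows:
- compound 1 `COc1ccc(N(C)c2ccnc(Cl)n2)cc1` gives 2120 nM
- compound 2 `COc1ccc(N(C)c2ccnc(Cl)n2)cc1F` gives 844 nM
- compound 3 `COc1ccc(N(C)c2ccnc(Cl)n2)cc1OCCCCBr` gives 168 nM

Compound 3 stands lowest of the three. Its two gaps are clear: a 5.0-fold lower number from compound 2 to compound 3 (0.70 log units; beyond the scatter) is a modest step, and a 13-fold lower number from compound 1 to compound 3 (1.10 log units; beyond the scatter) is a large one. Compound 4 `COc1ccc(N(C)c2ccnc(Cl)n2)cc1OCC[Se]C#N` has not yet been measured. Its change from compound 3 is a group of 3 heavy atoms (1 carbon, 1 nitrogen, 1 selenium; no ring) in place of a group of 3 heavy atoms (2 carbon, 1 bromine; no ring), on a saturated chain carbon, two bonds along the chain from an oxygen on an aromatic ring on a saturated chain carbon, two bonds along the chain from an oxygen on an aromatic ring. For the measured compounds named here, those two steps bear on this change only loosely: each brings in the whole 4-bromobutoxy group, and no measured step alters a chain already in place. The data therefore give no firm size. Starting from compound 3 at 168 nM in this assay, no step beyond the scatter is expected, with a slight lean towards a lower number. The estimated change is a 1.5-fold lower number from compound 3 to compound 4 (0.18 log units; within the scatter) and remains a rough guess. For compound 4 the estimated value is 110 nM with an expected range from 25 nM to 480 nM in this measurement.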

Compound 4, half-maximal inhibitory concentration: 1670 nM
Estimate against measurement, compound 4: 15-fold (1.18 log units) below; measured number above the stated range.
By their numbers in this assay, from the lowest: compound 3; then compounds 2, 4 and 1 (each within the scatter of the next, the first and the last beyond it).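

For the compounds shown here, this is the first measured change to a chain already in place, and in this assay the swap gives a 9.9-fold higher number from compound 3 to compound 4 (1.00 log units; beyond the scatter). The benefit seen with the 4-bromobutoxy group therefore does not carry over to every chain at this place on the ring. The new chain also leaves little to separate the compound from its simpler relatives, since a 2.0-fold higher number from compound 2 to compound 4 (0.30 log units; within the scatter) and a 1.3-fold lower number from compound 1 to compound 4 (0.10 log units; within the scatter) both lie within the scatter. No measurement here accounts for the loss.

Still open, as far as these compounds go, is whether the bromine, the selenium and nitrile end, or the length of the chain decides the result. An amine in place of the bromine, or a longer chain ending in bromine, would help to tell these apart.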